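The source may hold more compounds than are shown below. What is called first, only, known or untested is meant among the compounds shown, and "the series" means these compounds.

Measured so far, in a functional assay on HCT-116 cells (Homo sapiens) for cytotoxicity, read by MTT assay, with a stated time of 72 h; on this read-out lower numbers stand for stronger inhibition and higher numbers for weaker inhibition:

compound 1 `O=C1c2c[n+]([O-])c3ccccc3c2C(=O)c2c1c1ccccc1n2Cc1cn([C@H]2C[C@H](O)[C@@H](CO)O2)nn1`: 120 nM
compound 2 `O=C1c2c[n+]([O-])c3ccccc3c2C(=O)c2c1c1ccccc1n2CCN1CCCC1`: 270 nM
compound 3 `CC1(C)OC[C@H](Cn2cc(Cn3c4c(c5ccccc53)C(=O)c3c[n+]([O-])c5ccccc5c3C4=O)nn2)O1`: 130 nM

Compound 2 carries the highest number of the three in this assay; compound 3 sits nearest to it, compound 1 furthest, and both gaps lie beyond the scatter. Among the compounds with values here, the only one-place step recorded, a 1.1-fold higher number from compound 1 to compound 3 (0.03 log units; within the scatter), concerns the substituent on an aromatic nitrogen of the shared core and stays within the scatter; it does not touch the chain that distinguishes compound 2.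

Compound 4 `O=C1c2c[n+]([O-])c3ccccc3c2C(=O)c2c1c1ccccc1n2CCCCn1ccnc1` keeps the core of compound 2 and alters that chain: 2-(1H-imidazol-1-yl)ethyl in place of pyrrolidin-1-yl on a saturated chain carbon, two bonds along the chain from an aromatic nitrogen. Within the data shown here, no measured pair changes a chain substituent two bonds from the aromatic nitrogen, so nothing recorded bears directly on this step. Among the measured compounds shown here, the only thing the three numbers show is that the one compound with pyrrolidin-1-yl on the chain, compound 2, sits at the high end, while the two compounds with a different group on the core nitrogen sit lower.

For the measured compounds named here, with no step to lean on, the expected change is a 1.1-fold lower number from compound 2 to compound 4 (0.03 log units; within the scatter), not beyond the scatter in either direction, carrying a wide range. Compound 4 is therefore estimated at 250 nM in this assay. Its range is expected to run from 110 nM to 560 nM.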

Compound 4, half-maximal inhibitory concentration: 240 nM
The estimate for compound 4 lay 1.0-fold (0.02 log units) above the measured number; low and high end bracket the measured number.
By their numbers in this assay, from the lowest: compounds 1, 3, 4 and 2 (each within the scatter of the next, the first and the last beyond it).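

In this assay, the change at this saturated chain carbon, two bonds along the chain from an aromatic nitrogen, gives a 1.1-fold lower number from compound 2 to compound 4 (0.05 log units; within the scatter) and so shows that a five-membered aromatic ring with 2 hetero atoms can stand in for a five-membered non-aromatic ring with 1 hetero atom without a readable shift in the number, even with the chain lengthened. Cut one bond further out, the same difference reads 2-(pyrrolidin-1-yl)ethyl to 4-(1H-imidazol-1-yl)butyl, so ring type and chain length change together in this one step, and the step cannot separate them or show whether two separate effects cancel. Nothing at hand explains why the number stays within the scatter.

Still open, going by these compounds, is how each part acts alone, which 4-(pyrrolidin-1-yl)butyl or 2-(1H-imidazol-1-yl)ethyl on the aromatic nitrogen would show. Also open, on these data alone, is whether the chain end tolerates other groups, such as a primary amine, a carboxylic acid or a morpholine ring, to the same extent.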